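The source may hold more compounds than are shown below. What is called first, only, known or untested is meant among the compounds shown, and "the series" means these compounds.

Working notes on the series. Compound 1 `COc1ccc(-n2nncc2CN2C(=O)C3(C(C#N)=C(N)Oc4c3c3nc5ccccc5nc3c3ccccc43)c3ccccc32)cc1`, compound 2 `Cc1ccc(-n2nncc2CN2C(=O)C3(C(C#N)=C(N)Oc4c3c3nc5ccccc5nc3c3ccccc43)c3ccccc32)cc1C` and compound 3 `CC(=O)Nc1ccc(-n2nncc2CN2C(=O)C3(C(C#N)=C(N)Oc4c(N)cc5nc6ccccc6nc5c43)c3ccccc32)cc1` share one core and differ only in the group on an aromatic nitrogen. In an ADME assay on HUVEC cells (Homo sapiens) for antiproliferative activity, read by MTT assay, with a stated time of 48 h (a higher number here means a weaker inhibitor, a lower number a stronger inhibitor), compound 1 gives > 50000 nM, which is a limit of the assay. Compound 2 gives > 50000 nM in this assay, again a limit. Compound 3 gives > 50000 nM in this assay, also a limit. The step that the two limits leave unreadable from compound 1 to compound 2 is therefore not readable. Compound 3 thus stands at the limit of > 50000 nM in this assay, at which 3 of the 3 values shown sit. Compound 4 `N#CC1=C(N)Oc2c(N)cc3nc4ccccc4nc3c2C12C(=O)N(Cc1cnnn1-c1ccc(Cl)cc1[N+](=O)[O-])c1ccccc12` brings the next change: 4-chloro-2-nitrophenyl in place of 4-acetamidophenyl on an aromatic nitrogen. Among the measured compounds shown here, no measured step has a readable size, so no shift beyond the scatter can be expected. Compound 4 is expected near 60000 nM, with an estimated range of 20000 nM to 200000 nM, most likely again reported as a limit. The estimated step that the limit leaves unreadable from compound 3 to compound 4 is expected to stay within the scatter.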

Compound 4, half-maximal inhibitory concentration: > 50000 nM
Compound 4: only a limit was reported; the forecaster's own chance of this, stated with the estimate: 85%; the middle value lies beyond the limit too.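

Among the compounds shown here, compound 3 and compound 4 both stand at a limit in this assay, and no step between them can be read. The compounds shown leave open whether any group on the aromatic nitrogen gives a readable value in this assay.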